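The compounds below may be only part of what the source reports. "The series", "measured", "known", "first", "only" and "open" are said of these compounds alone.

Going by the values given here, in an ADME assay on BHK cells (Mesocricetus auratus) for cytotoxicity, read by MTT assay, with a stated time of 96 h (a lower number here means that less compound is tolerated, a higher number that more compound is tolerated), compound 1 `FC(F)(F)c1cccc(NC(=S)Nc2ccc(I)cc2)c1` gives 9400 nM, the lowest of the two numbers measured so far. Its nearest neighbour is compound 2 `FC(F)(F)c1cccc(NC(=S)Nc2ccccc2Br)c1`, which gives 59000 nM; that change is a 6.3-fold higher number from compound 1 to compound 2 (0.80 log units; beyond the scatter). Compound 3 `CC(=O)NC(=S)Nc1cccc(C(F)(F)F)c1` gives > 100000 nM, which is a limit of the assay rather than a number (the limit of > 100000 nM in this assay, at which 1 of the 3 values shown sits). From compound 1 to compound 3 the change is an at least 10-fold higher number from compound 1 to compound 3 (1.02 log units; beyond the scatter), and from compound 2 to compound 3 it is an at least 1.6-fold higher number from compound 2 to compound 3 (0.22 log units; that floor lies within the scatter).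

Compound 4 `CCCC[C@H]1CC[C@H](c2ccc(NC(=S)Nc3cccc(C(F)(F)F)c3)cc2)CC1` has not yet been measured. It differs from compound 1 in one place: 4-butylcyclohexyl in place of iodo on an aromatic carbon. Both measured steps away from compound 1 swap the whole 4-iodophenyl for a different group on the amide-type nitrogen, and both raise the number, one modestly and one by a large margin that ends at a limit. Neither keeps the ring and changes only the group on its aromatic carbon, as the step to compound 4 does, so they bear on it only loosely and give no direction to lean on. A modest step at most is therefore expected, within or just beyond the scatter. Compound 4 is estimated at 5000 nM, with a range from 1500 nM to 20000 nM, which means an expected step of a 1.9-fold lower number from compound 1 to compound 4 (0.27 log units; within the scatter).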

Compound 4, half-maximal cytotoxic concentration: 9500 nM
Estimate against measurement, compound 4: 1.9-fold (0.28 log units) below; measured number inside the range.
By their numbers in this assay, from the lowest: compounds 1 and 4 (each within the scatter of the next); then compound 2. At a limit, above all of these: compound 3.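

In this assay, this is the first step shown that keeps the ring of compound 1 and changes only the group on its aromatic carbon, and it gives a 1.0-fold higher number from compound 1 to compound 4 (0.00 log units; within the scatter) for the swap of iodo for 4-butylcyclohexyl. Going by these compounds alone, at this carbon, then, a single iodine atom and a group of 10 heavy atoms, with a non-aromatic ring and 2 defined stereocentres, cannot be told apart by this read-out, even though the two groups differ greatly in size by atom count; the earlier steps beyond the scatter replaced the whole 4-iodophenyl, so they could not show this. Nothing measured among the data shown accounts for this result.

From the compounds shown here alone, these two groups are only two points, so it remains open whether an amine, a carboxylic acid or a longer chain on the same carbon would also leave the number unmoved. Going by these compounds, it also remains open whether the other stereoisomer of the 4-butylcyclohexyl group would behave in the same way, and whether a shorter chain on the cyclohexyl ring would matter.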